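This account rests on a few compounds, and the source may have more. Where it says the series, first, only, none or still open, it means among the compounds named here.

Working notes on the series. Compound 1 `CCc1ccccc1-c1nc(NCc2ccc(-c3cccnc3)cc2)c2ccccc2n1` gives 780 nM in an assay on a protein complex for inhibition of ubiquitin carboxyl-terminal hydrolase 1/WD repeat-containing protein 48 (Homo sapiens), read by fluorescence; on this read-out lower numbers stand for stronger inhibition and higher numbers for weaker inhibition. Compound 2 `CC(C)c1ccccc1-c1nc(NCc2ccc(-c3cccnc3)cc2)c2ccccc2n1` gives 180 nM in this assay. The change between them is methyl in place of hydrogen on a saturated chain carbon bound to an aromatic carbon and a saturated chain carbon and it made a 4.3-fold lower number from compound 1 to compound 2 (0.64 log units; beyond the scatter). Compound 3 `Cc1cnc(-c2ccccc2CO)nc1NCc1ccc(-c2cccnc2)cc1` gives 10500 nM in this assay, the highest number of the three measured; the difference between its core and the core of compound 1 is not broken down here.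

Compound 4 `Cc1cnc(-c2ccccc2C(C)O)nc1NCc1ccc(-c2cccnc2)cc1` is not yet measured. It differs from compound 3 by methyl in place of hydrogen on a saturated chain carbon bound to an aromatic carbon and an oxygen on a saturated carbon. Among the compounds with values here, this is the same kind of change as the one from compound 1 to compound 2, not the same: there the place is on a saturated chain carbon bound to an aromatic carbon and a saturated chain carbon, here it is on a saturated chain carbon bound to an aromatic carbon and an oxygen on a saturated carbon, and the core is also a different one. Within the data shown here, the expectation rests only on the pair of compound 1 and compound 2, because a 4.3-fold lower number from compound 1 to compound 2 (0.64 log units; beyond the scatter) is the single precedent available. For compound 4 the expected step is a 2.3-fold lower number from compound 3 to compound 4 (0.37 log units; beyond the scatter), hedged toward a smaller gain given the changed surroundings. Compound 4 is therefore estimated at 4500 nM, with a likely range from 1500 nM to 13000 nM.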

Compound 4, half-maximal inhibitory concentration: 2000 nM
Estimate against measurement, compound 4: 2.3-fold (0.35 log units) above; low and high end bracket the measured number.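

Methyl in place of hydrogen on a saturated chain carbon bound to an aromatic carbon and an oxygen on a saturated carbon gives, in this assay, a 5.3-fold lower number from compound 3 to compound 4 (0.72 log units; beyond the scatter). Set beside the earlier step, the size of the change holds on both cores, whether that carbon also carries a saturated chain carbon or an oxygen on a saturated carbon: the same change on two cores in this assay, a 4.3-fold lower number (0.64 log units; beyond the scatter) from compound 1 to compound 2 and a 5.3-fold lower number (0.72 log units; beyond the scatter) from compound 3 to compound 4, 1.2-fold (0.08 log units) apart, within the scatter of two such steps. These two pairs show agreement on these two cores only; they give no rule for any other core in the series and do not show why the step has this size.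

Open, on these data alone, is whether a longer chain, such as 1-hydroxypropyl in place of 1-hydroxyethyl, would continue the step or reverse it. Also open, as far as these compounds go, is whether an amine in place of the hydroxyl of the 1-hydroxyethyl group would keep the number reached by compound 4.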